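Hydroxyphenyl Swap Carried From One Core To Another

The source may hold more compounds than are shown below. What is called first, only, known or untested is meant among the compounds shown, and "the series" means these compounds.

Measured so far in a functional assay on HeLa cells (Homo sapiens) for cytotoxicity, read by CCK-8 assay; on this read-out lower numbers stand for stronger inhibition and higher numbers for weaker inhibition:
compound 1 `Oc1cccc(-c2cc(-c3cccs3)cc(-c3cccc(O)c3)n2)c1` gives 1690 nM
compound 2 `Oc1ccc(-c2cc(-c3cccs3)cc(-c3cccc(O)c3)n2)cc1` gives 4140 nM
compound 3 `Oc1cccc(-c2cc(-c3ccoc3)cc(-c3cccc(O)c3)n2)c1` gives 4630 nM

Compound 1 and compound 2 differ by 4-hydroxyphenyl in place of 3-hydroxyphenyl on an aromatic carbon; this step made a 2.4-fold higher number from compound 1 to compound 2 (0.39 log units; beyond the scatter). The cores of compound 1 and compound 3 differ by furan-3-yl in place of thiophen-2-yl on an aromatic carbon, and that step made a 2.7-fold higher number from compound 1 to compound 3 (0.44 log units; beyond the scatter). Compound 3 has the highest number of the three; the gap to compound 2 lies within the scatter, the gap to compound 1 beyond it.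

Compound 4 `Oc1ccc(-c2cc(-c3ccoc3)cc(-c3cccc(O)c3)n2)cc1` is not yet measured. It differs from compound 3 by 4-hydroxyphenyl in place of 3-hydroxyphenyl on an aromatic carbon. The surroundings of the place are not identical to those in the first pair: in compound 1 the place is meta to a thiophen-2-yl group, in compound 3 it is meta to a furan-3-yl group, so this is the same kind of change rather than the same change.

Compound 4 is expected to give 10000 nM, with a likely range from 5000 nM to 22000 nM. For the measured compounds named here, the expected step, a 2.2-fold higher number from compound 3 to compound 4 (0.33 log units; beyond the scatter), is set beside the earlier one because a 2.4-fold higher number from compound 1 to compound 2 (0.39 log units; beyond the scatter) is the only measured instance of this kind of change, applied to the value of compound 3, 4630 nM. Going by the values given here, only one prior instance exists, so the range is kept wide.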

Compound 4, half-maximal inhibitory concentration: 3310 nM
Compound 4: the middle estimate sits 3.0-fold (0.48 log units) above what was measured, outside the stated range (below it).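

In this assay, the change to 4-hydroxyphenyl from 3-hydroxyphenyl gave a 1.4-fold lower number from compound 3 to compound 4 (0.15 log units; within the scatter), so the rise seen with the thiophen-2-yl group does not carry over to the furan-3-yl core: the same change on two cores in this assay, a 2.4-fold higher number (0.39 log units; beyond the scatter) from compound 1 to compound 2 and a 1.4-fold lower number (0.15 log units; within the scatter) from compound 3 to compound 4, 3.4-fold (0.53 log units) apart, beyond the scatter of two such steps

Read the other way round, furan-3-yl in place of thiophen-2-yl gave a 1.3-fold lower number from compound 2 to compound 4 (0.10 log units; within the scatter), so that change also fails to carry over, here from the 3-hydroxyphenyl compounds to the 4-hydroxyphenyl ones: the same change on two cores in this assay, a 2.7-fold higher number (0.44 log units; beyond the scatter) from compound 1 to compound 3 and a 1.3-fold lower number (0.10 log units; within the scatter) from compound 2 to compound 4, 3.4-fold (0.53 log units) apart, beyond the scatter of two such steps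

The two changes are therefore not additive across these four compounds, but this rests on a single square of compounds: it gives no reason for the mismatch, no general rule for the series, and no direction for either step that lies within the scatter.

Still open, as far as these compounds go, is whether the same dependence appears with a furan-2-yl or thiophen-3-yl group on the shared core. Also open, from the compounds shown here alone, is how an amine or a carboxylic acid in place of the hydroxyl group would behave on either core.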